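A few compounds are considered here, and "the series" means these few. Any claim that something is new, unique, unknown or untested is made for them only; others in the source may bear on it.

Compound 1 `C[N+](C)(C)Cc1cn(Cc2ccccc2)c2ccccc12` gives 4200 nM in an assay on HEK293 cells for antagonist activity at Neuronal acetylcholine receptor; alpha4/beta2 (Homo sapiens), read by calcium flux; a lower number here means a stronger inhibitor, a higher number a weaker inhibitor.
Compound 2 `C[N+](C)(C)Cc1cn(Cc2cccc(O)c2)c2ccccc12` gives 14700 nM in this assay.

Going by the values given here, compound 2 stands at the higher of the two numbers obtained so far; its nearest neighbour is compound 1, and the only measured step, a 3.5-fold higher number from compound 1 to compound 2 (0.54 log units; beyond the scatter), separates them. Among the compounds with values here, that step is the sole guide for the next change. Compound 3 `C[N+](C)(C)Cc1cn(Cc2ccc(O)cc2)c2ccccc12` has not yet been measured in this assay; it differs from compound 2 in the way counted here: 4-hydroxyphenyl in place of 3-hydroxyphenyl on a saturated chain carbon bound to an aromatic nitrogen. Both compounds carry the same hydroxyphenyl group on the saturated chain carbon bound to the aromatic nitrogen, and only the position of the hydroxy on that ring is moved. The measured step from compound 1 to compound 2 shows that placing a hydroxy on this ring cost activity in this assay, but it says nothing about whether one position of the hydroxy differs from another. Within the data shown here, with no step in hand for such a move, compound 3 is expected to fall near compound 2, and the step of a 1.5-fold lower number from compound 2 to compound 3 (0.17 log units; within the scatter) is estimated to stay within the scatter. Compound 3 is therefore estimated at 10000 nM, with a plausible range from 3000 nM to 35000 nM.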

Compound 3, half-maximal inhibitory concentration: 24900 nM
Compound 3: the middle estimate sits 2.5-fold (0.40 log units) below what was measured; measured number inside the range.
By their numbers in this assay, from the lowest: compound 1; then compounds 2 and 3 (each within the scatter of the next).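

With 4-hydroxyphenyl in place of 3-hydroxyphenyl on a saturated chain carbon bound to an aromatic nitrogen, this assay shows a 1.7-fold higher number from compound 2 to compound 3 (0.23 log units; within the scatter) and so does not tell these two placements of the hydroxy apart. The comparison with the unsubstituted compound adds that the earlier penalty is not tied to the 3-hydroxyphenyl group alone: hydroxy in place of hydrogen on an aromatic carbon gives a 5.9-fold higher number from compound 1 to compound 3 (0.77 log units; beyond the scatter) and, like the first hydroxy change, lies beyond the scatter, so compound 1 retains the lowest number among these three compounds. No measurement shown here accounts for the result or explains why the two hydroxyphenyl compounds stand together.

The compounds shown leave open whether the penalty belongs to the hydroxy itself or would also appear with a methoxy group, an amine or a carboxylic acid on the same ring. They also leave open whether any substituent on this ring can bring the number below that of compound 1, and whether a longer chain between the ring and the aromatic nitrogen would change the effect of the hydroxy.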